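The source may report more compounds than this note shows. Statements on the series, on what has been measured and on what is new or still open speak of the compounds shown alone.

Compound 1 `N#Cc1c(N)cccc1NC(=O)C(=O)O`: 21.2%
Compound 2 `CCNc1cccc(NC(=O)C(=O)O)c1C#N`: 58.9%

Two compounds share the core shown above and have been measured in a functional assay on the whole organism for inhibition, with Rattus norvegicus as the target, at a dose of 1 mg/kg by the oral route; on this read-out lower numbers stand for less inhibition and higher numbers for more inhibition at the one dose given (going by the name of the read-out). Compound 1 gives 21.2%, and compound 2 gives 58.9%. Among the measured compounds shown here, compound 2 stands highest of the two numbers; its nearest neighbour is compound 1, and the step of a number 37.7 percentage points higher from compound 1 to compound 2 (beyond the scatter) is the only measured step in the set. That step, ethyl in place of hydrogen on a nitrogen on an aromatic ring, shows that a change at this part of the core can move the read-out by a large amount.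

Compound 3 `COC(=O)c1cccc(NC(=O)C(=O)O)c1C#N` has not yet been measured in this assay. The change from compound 2 is methoxycarbonyl in place of ethylamino on an aromatic carbon. Nothing measured carries the same group, so only the size of the one known step can guide the expectation: the position is sensitive, but the direction of a methoxycarbonyl in place of ethylamino is not shown by any pair. Compound 3 is therefore estimated at 40%, within 15% to 68%, the expected step being a number 18.9 percentage points lower from compound 2 to compound 3 (beyond the scatter).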

Compound 3, a percentage reported as inhibition, in the whole organism at one dose (the size of the read-out at that dose, not a potency): 24.5%
Beside the measured number, compound 3's estimate is 15.5 percentage points above it, within the range that was stated.
By their numbers in this assay, from the lowest: compounds 1 and 3 (each within the scatter of the next); then compound 2.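

In this assay, methoxycarbonyl in place of ethylamino on the aromatic carbon gives a number 34.4 percentage points lower from compound 2 to compound 3 (beyond the scatter) and so supplies the first measured step downward at this position. Methoxycarbonyl in place of amino gives a number 3.3 percentage points higher from compound 1 to compound 3 (within the scatter) and so leaves compound 1 and compound 3 indistinguishable on this read-out, although the two groups share little in name or atom count. Of the three groups measured on this carbon, ethylamino in compound 2 alone stands apart from the others, which shows that the large step seen earlier belongs to that particular group and is not gained by simply replacing amino with something larger. No measurement available here bears on why these groups behave as they do. The compounds shown leave open whether the effect of ethylamino depends on its chain, which a longer chain such as propylamino or a branched one such as isopropylamino on the same nitrogen would test. They also leave open whether any group without a nitrogen on this carbon can match compound 2, as a simple propyl chain or a methoxy group might show.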